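Moving the Anilide Aryl While Three Analogues Sit at the Limit

A few compounds are considered here, and "the series" means these few. Any claim that something is new, unique, unknown or untested is made for them only; others in the source may bear on it.

Compound 1 `C=CC1=C(C(=O)Nc2ccccc2OC)C(c2ccc(F)cc2)OC1` in a functional assay on A549 cells (Homo sapiens) for cytotoxicity, read by MTT assay, with a stated time of 24 h (on this read-out lower numbers stand for stronger inhibition and higher numbers for weaker inhibition), gives > 100000 nM, a limit of the assay rather than a number.
Compound 2 `C=CC1=C(C(=O)Nc2ccccc2OC)C(c2ccc(OC)cc2)OC1` in this assay gives > 100000 nM, also a limit.
Compound 3 `C=CC1=C(C(=O)Nc2ccccc2OC)C(c2ccc(Cl)c(Cl)c2)OC1` in this assay gives > 100000 nM, again a limit.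

All three values sit at the limit of > 100000 nM in this assay, at which 3 of the 3 values shown sit, so compound 2 stands at the limit and cannot be told apart from the other two on these numbers. The steps among the measured compounds, a step that the two limits leave unreadable from compound 1 to compound 2, a step that the two limits leave unreadable from compound 1 to compound 3 and a step that the two limits leave unreadable from compound 2 to compound 3, each alter the aryl on the saturated ring carbon, and none can be given a size.

Compound 4 `C=CC1=C(C(=O)Nc2ccc(OCC)cc2)C(c2ccc(OC)cc2)OC1` differs from compound 2 at the amide-type nitrogen: 4-ethoxyphenyl in place of 2-methoxyphenyl on an amide-type nitrogen. Among the measured compounds shown here, no measured step touches this part of the molecule, so none bears on the change directly; the only guidance is that three variations elsewhere left every compound at the limit. The step from compound 2 to compound 4 in this assay is therefore expected to be a step that the limit leaves unreadable from compound 2 to compound 4, with no readable direction. Compound 4 is estimated at 150000 nM, with a range from 50000 nM to 500000 nM, and most likely only a limit will be reported.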

Compound 4, half-maximal inhibitory concentration: 17600 nM
Compound 4: the middle estimate sits 8.5-fold (0.93 log units) above what was measured; measured number outside the range, below it.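

The aryl on the amide-type nitrogen proves to be a place where the read-out can move: in this assay, 4-ethoxyphenyl in place of 2-methoxyphenyl gives an at least 5.6-fold lower number from compound 2 to compound 4 (0.75 log units; beyond the scatter), whereas the three changes on the saturated ring carbon cannot be read at all. Compound 4 therefore gives this small set its first true number rather than a limit. The step is a minimum and not a full size, since its starting point is a limit: the limit of > 100000 nM in this assay, at which 3 of the 4 values shown sit.

Compound 4 differs from compound 2 in both the ether chain and its numbered place on the ring, and the compounds shown do not separate the two. They also leave open how a plain phenyl or an aryl carrying an amine would read on the amide-type nitrogen, and whether the aryl on the saturated ring carbon matters once 4-ethoxyphenyl is present.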